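Halogen Exchange on an Aromatic Carbon: Fluoro to Bromo

A few compounds are considered here, and "the series" means these few. Any claim that something is new, unique, unknown or untested is made for them only; others in the source may bear on it.

Two measured compounds share one core and differ only in the halogen carried on an aromatic carbon. Compound 1 `COc1ccc(C(/C=C/c2ccc(Cl)cc2)=N/O)cc1` gives 11500 nM in a functional assay (Mus musculus, strain Balb/c) for inhibition, read by ELISA, with a stated time of 72 h (on this read-out lower numbers stand for stronger inhibition and higher numbers for weaker inhibition), and compound 2 `COc1ccc(C(/C=C/c2ccc(F)cc2)=N/O)cc1` gives 11000 nM in this assay. The step of a 1.0-fold lower number from compound 1 to compound 2 (0.02 log units; within the scatter) shows that the exchange of chloro for fluoro left the read-out essentially where it was. For the measured compounds named here, compound 2 therefore stands alongside compound 1, its only neighbour, the two numbers lying within the scatter of each other. Compound 3 `COc1ccc(C(/C=C/c2ccc(Br)cc2)=N/O)cc1` has not yet been measured; it differs from compound 2 by bromo in place of fluoro on an aromatic carbon. Going by the values given here, only one measured step bears on this change, a 1.0-fold lower number from compound 1 to compound 2 (0.02 log units; within the scatter), and it lay within the scatter; on that basis compound 3 is expected to show no step beyond the scatter, no change at the digits printed from compound 2 to compound 3 (within the scatter). Compound 3 is estimated at 11000 nM, with a range from 5500 nM to 22000 nM.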

Compound 3, half-maximal inhibitory concentration: 13900 nM
For compound 3 the middle estimate is 1.3-fold (0.10 log units) below the measured one, within the range that was stated.
By their numbers in this assay, from the lowest: compounds 2, 1 and 3 (each within the scatter of the next).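

In this assay the move to the heaviest of the three halogens again stays within the scatter, with a 1.3-fold higher number from compound 2 to compound 3 (0.10 log units; within the scatter) and a 1.2-fold higher number from compound 1 to compound 3 (0.08 log units; within the scatter) both printed as such. For the compounds shown here, the earlier compounds offered only the single exchange between chloro and fluoro, whereas fluoro, chloro and bromo on this aromatic carbon, para to a large group, now all lie within the scatter of one another, so no order among the three can be drawn. No supporting measurement is available to explain why the read-out holds across these halogens.

The compounds shown leave open whether an amine, a carboxylic acid or a longer alkyl chain at this position would move the number beyond the scatter. They also leave open how the read-out would respond with plain hydrogen on this carbon.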